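The compounds below may be only part of what the source reports. "The series", "measured", "known", "first", "only" and "open" are said of these compounds alone.

Going by the values given here, compound 1 `O=C1OC[C@H](Cc2cccc(O)c2)[C@H]1Cc1ccc(Cl)c(Cl)c1` gives 48000 nM in a functional assay on HL-60 cells (Homo sapiens) for cytotoxicity, read by WST assay, with a stated time of 48 h (on this read-out lower numbers stand for an effect already at smaller amounts and higher numbers for an effect only at larger amounts of compound), the highest of the two numbers so far; compound 2 `COc1ccc(C[C@H]2COC(=O)[C@@H]2Cc2ccc(Cl)c(Cl)c2)cc1O` gives 32000 nM, and the step of a 1.5-fold lower number from compound 1 to compound 2 (0.18 log units; within the scatter) lies within the scatter. Compound 3 `O=C1OC[C@H](Cc2ccc(F)c(F)c2)[C@H]1Cc1ccc(Cl)c(Cl)c1` differs from compound 1 in one place: 3,4-difluorophenyl in place of 3-hydroxyphenyl on a saturated chain carbon bound to a saturated ring carbon. Among the compounds with values here, no measured step touches that ring; the one step known, a 1.5-fold lower number from compound 1 to compound 2 (0.18 log units; within the scatter), concerns another ring and was within the scatter. The change to compound 3 is therefore expected to give no step beyond the scatter, a 1.2-fold lower number from compound 1 to compound 3 (0.08 log units; within the scatter). For compound 3 the estimate is 40000 nM, with a range from 15000 nM to 110000 nM.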

Compound 3, half-maximal effective concentration: 25000 nM
The estimate for compound 3 lay 1.6-fold (0.20 log units) above the measured number, and the stated range covers the measured number.
By their numbers in this assay, from the lowest: compounds 3, 2 and 1 (each within the scatter of the next).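

In this assay, the exchange of 3-hydroxyphenyl for 3,4-difluorophenyl on a saturated chain carbon bound to a saturated ring carbon gives a 1.9-fold lower number from compound 1 to compound 3 (0.28 log units; within the scatter). The whole ring at this position was therefore replaced, and its hydroxyl lost, without a step beyond the scatter. No available evidence bears on this result. Still open, as far as these compounds go, is whether an amine or a carboxylic acid on this ring, or a longer chain in place of the saturated chain carbon, would give a step beyond the scatter.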